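The source may report more compounds than this note shows. Statements on the series, on what has been measured and on what is new or still open speak of the compounds shown alone.

Working notes on the series.

Compound 2 `COc1ccc2c(c1)NC(=O)CN2c1nc(COCCCC(=O)NO)nc2ccccc12` stands at the high end of the three numbers in a functional assay on KB cells (Homo sapiens) for inhibition, read by sulforhodamine B assay, with a stated time of 48 h; on this read-out lower numbers stand for stronger inhibition of growth and higher numbers for weaker inhibition of growth: compound 2 gives 307 nM, while compound 1 `COc1ccc2c(c1)NC(=O)CN2c1nc(OCC2CC2)nc2ccccc12` gives 14.2 nM and compound 3 `COc1ccc2c(c1)NC(=O)CN2c1nc(N2CCCC2)nc2ccccc12` gives 33.2 nM. Both steps away from compound 2 are beyond the scatter: a 22-fold higher number from compound 1 to compound 2 (1.33 log units; beyond the scatter) read in reverse, and a 9.2-fold lower number from compound 2 to compound 3 (0.97 log units; beyond the scatter). The step to compound 4 `COc1ccc2c(c1)NC(=O)CN2c1nc(NC2CCCC2)nc2ccccc12` is cyclopentylamino in place of (3-(hydroxycarbamoyl)propoxy)methyl on an aromatic carbon.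

The step bearing most directly on it is a 9.2-fold lower number from compound 2 to compound 3 (0.97 log units; beyond the scatter), where the same group left and pyrrolidin-1-yl entered at the same aromatic carbon; a 2.3-fold higher number from compound 1 to compound 3 (0.37 log units; beyond the scatter) adds that pyrrolidin-1-yl sits close to cyclopropylmethoxy. Cyclopentylamino shares the five-membered carbon ring and the nitrogen attachment counted for compound 3, so a large lower number in this assay is expected. The step expected from compound 2 to compound 4 is an 8.8-fold lower number from compound 2 to compound 4 (0.94 log units; beyond the scatter). Compound 4 is estimated at 35 nM in this assay, with a range from 12 nM to 110 nM.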

Compound 4, concentration for 50% growth inhibition: 6.92 nM
Beside the measured number, compound 4's estimate is 5.1-fold (0.70 log units) above it; measured number outside the range, below it.
By their numbers in this assay, from the lowest: compound 4; then compound 1; then compound 3; then compound 2.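

At the aromatic carbon between two ring nitrogen atoms, cyclopentylamino gives the lowest number of the four compounds in this assay, with a 44-fold lower number from compound 2 to compound 4 (1.65 log units; beyond the scatter) exceeding the step to pyrrolidin-1-yl from the same starting point. The two nitrogen-attached five-membered rings are not interchangeable here: a 4.8-fold lower number from compound 3 to compound 4 (0.68 log units; beyond the scatter) separates the ring of carbon only, with its hydrogen-bond donor, from pyrrolidin-1-yl. The position also tolerates a replacement for cyclopropylmethoxy that goes further down, with a 2.1-fold lower number from compound 1 to compound 4 (0.31 log units; beyond the scatter), a modest step but one beyond the scatter.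

Nothing shown accounts for the gap between these two amino groups. Going by these compounds, whether cyclohexylamino, cyclobutylamino or a cyclopentylmethylamino group would continue the trend at this position remains open.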